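Extending the methoxy group of compound 2

This account rests on a few compounds, and the source may have more. Where it says the series, first, only, none or still open, it means among the compounds named here.

Measured in an ADME assay on the whole organism (strain Sprague-Dawley) for metabolic stability, with Rattus norvegicus as the target; a lower number here means that the compound disappears faster, a higher number that the compound lasts longer:
- compound 1 `COc1ccc2c(OCc3nnc4ccc(-c5cc(F)c(F)c(F)c5)nn34)ccnc2c1` gives 3.5 h 
- compound 2 `COc1cnc2ccn([C@H](C)c3nnc4c(F)cc(-c5cc(C)no5)cn34)c(=O)c2c1` gives 1.1 h 

Compound 2 has the lower of the two numbers in this assay and compound 1 stands higher, with a gap beyond the usual scatter. These two compounds differ in more than one place, so their gap says nothing about a single change.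

Compound 3 `COCCOc1cnc2ccn([C@H](C)c3nnc4c(F)cc(-c5cc(C)no5)cn34)c(=O)c2c1` departs from compound 2 in one place (methoxymethyl in place of hydrogen on a saturated chain carbon bound to an oxygen on an aromatic ring), with methoxymethyl in place of hydrogen on a saturated chain carbon bound to an oxygen on an aromatic ring. This turns methoxy to 2-methoxyethoxy. Within the data shown here, no measured pair shows this change, so its size in this assay remains a judgement. Compound 2 at 1.1 h is the only close reference. A small move towards a shorter half-life is expected, probably none beyond the scatter. The expected change is a 1.2-fold lower number from compound 2 to compound 3 (0.09 log units; within the scatter) and a move in the other direction is not excluded. Compound 3 is estimated at 0.9 h (range 0.45 h to 1.8 h).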

Compound 3, half-life: 2.9 h
Compound 3: middle estimate off by 3.2-fold (0.51 log units), on the low side, and the stated range ends below it.
By their numbers in this assay, from the lowest: compound 2; then compounds 3 and 1 (each within the scatter of the next).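

In this assay, among these compounds, the change from methoxy to 2-methoxyethoxy brings a 2.6-fold higher number from compound 2 to compound 3 (0.42 log units; beyond the scatter), and this is the only step so far that isolates a single place. It shows that the half-life responds to what sits on the saturated chain carbon bound to an oxygen on an aromatic ring, and that methoxymethyl in place of hydrogen there moves the number up rather than down. Nothing measured on these compounds bears on what lies behind this rise, so it stands as an observation on one pair only.

Still open, from the compounds shown here alone, is whether the rise follows the added chain length or the oxygen within the added chain: a plain propoxy group, a 2-hydroxyethoxy group or a 2-(dimethylamino)ethoxy group at the same place would help separate these readings. Also open, going by these compounds, is whether the same change would have a similar effect on the core of compound 1, which differs from compound 2 in more than one place and so gives no guidance on this point.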